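A Third Methoxy Group on the Amide Analogue

A few compounds are considered here, and "the series" means these few. Any claim that something is new, unique, unknown or untested is made for them only; others in the source may bear on it.

Compound 1 `COc1ccc(C(=O)/C=C/c2ccccc2-c2ccc(F)nc2)cc1` is the starting point. In a functional assay on HepG2 cells (Homo sapiens) for antiproliferative activity, read by sulforhodamine B assay, with a stated time of 48 h (a lower number here means a stronger inhibitor, a higher number a weaker inhibitor), compound 1 gives 8200 nM. Compound 2 `COc1ccc(C(=O)/C=C/c2ccccc2-c2ccc(F)nc2)cc1OC` differs from it in a single spot: methoxy in place of hydrogen on an aromatic carbon. In this assay compound 2 gives 17000 nM, and the step is a 2.1-fold higher number from compound 1 to compound 2 (0.32 log units; beyond the scatter). Adding the methoxy group therefore weakened the inhibitor modestly.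

Compound 3 `COc1ccc(CNC(=O)c2ccccc2-c2ccc(F)cc2)cc1OC` carries a different core; the difference between the two cores is not broken down here. In this assay compound 3 gives only a limit of the assay, > 50000 nM, not a number. This is the limit of > 50000 nM in this assay, at which 1 of the 3 values shown sits.

Compound 4 `COc1cc(CNC(=O)c2ccccc2-c2ccc(F)cc2)cc(OC)c1OC` has not been measured yet. It differs from compound 3 by methoxy in place of hydrogen on an aromatic carbon. Among the compounds with values here, this is the same kind of change as the one from compound 1 to compound 2, but not the same: the entering methoxy of compound 4 sits ortho to a methoxy group, meta to a large group and also meta to a methoxy group, whereas in compound 2 it sits ortho to a methoxy group and meta to a large group only.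

Compound 4 is expected to stay weak, because compound 3 already sits at the limit > 50000 nM and because the earlier step of a 2.1-fold higher number from compound 1 to compound 2 (0.32 log units; beyond the scatter) made the number higher rather than lower. The expected step from compound 3 is a step that the limit leaves unreadable from compound 3 to compound 4. For compound 4 in this assay the estimate is 90000 nM, with a range from 35000 nM to 250000 nM, and most likely the assay will again report only a limit.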

Compound 4, half-maximal inhibitory concentration: > 50000 nM
Compound 4: only a limit was reported; the forecaster's own chance of this, stated with the estimate: 85%; the middle value lies beyond the limit too.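

In this assay compound 4 gives > 50000 nM, a limit of the assay and not a number. Compound 3 also carries only a limit, so no step can be read between compound 3 and compound 4. Both compounds end at the same limit: the limit of > 50000 nM in this assay, at which 2 of the 4 values shown sit.

The compounds shown leave open whether the methoxy group entering in compound 4 changes activity on the core of compound 3 at all, in either direction.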